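The source may hold more compounds than are shown below. What is called first, only, known or untested is meant among the compounds shown, and "the series" means these compounds.

Measured in a functional assay on the whole organism (strain Sprague-Dawley) for inhibition, with Rattus norvegicus as the target, read by paw edema, with stated times of 30 min and 3 h, at a dose of 80 mg/kg by the oral route; on this read-out higher numbers stand for more inhibition at the one dose given (going by the name of the read-out) and lower numbers for less inhibition:

Compound 1 `Cc1nc2ccccc2c(=O)n1NS(=O)(=O)c1ccccc1` gives 77.3%
Compound 2 `Cc1ccc(S(=O)(=O)Nn2c(C)nc3ccccc3c2=O)cc1` gives 83.9%
Compound 3 `Cc1ccc(S(=O)(=O)Nn2c(CO[N+](=O)[O-])nc3ccccc3c2=O)cc1` gives 71.6%

Compound 2 has the highest of the three numbers, but its lead over compound 1 is slight: the step of a number 6.6 percentage points higher from compound 1 to compound 2 (within the scatter) falls within the usual scatter, so the two cannot be told apart. Only compound 3 lies clearly apart, the step of a number 12.3 percentage points lower from compound 2 to compound 3 (beyond the scatter) being beyond the scatter.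

Compound 4 `CC(=O)Nc1ccc(S(=O)(=O)Nn2c(C)nc3ccccc3c2=O)cc1` differs from compound 2 at one spot: acetamido in place of methyl on an aromatic carbon. For the measured compounds named here, no measured step swaps methyl for acetamido. Going by the values given here, the one step that touches the same spot, a number 6.6 percentage points higher from compound 1 to compound 2 (within the scatter), stayed within the scatter when a methyl replaced hydrogen there. The step of a number 12.3 percentage points lower from compound 2 to compound 3 (beyond the scatter) concerns a different place, the saturated chain carbon, and so says little about this change. On that slim basis the step to compound 4 is expected to stay within the scatter, perhaps leaning slightly lower: a number 5.9 percentage points lower from compound 2 to compound 4 (within the scatter). Compound 4 is therefore estimated at 78%, with a likely range from 62% to 92%.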

Compound 4, a percentage reported as inhibition, in the whole organism at one dose (the size of the read-out at that dose, not a potency): 95.7%
Compound 4: the middle estimate sits 17.7 percentage points below what was measured; measured number outside the range, above it.
By their numbers in this assay, from the lowest: compounds 3, 1 and 2 (each within the scatter of the next, the first and the last beyond it); then compound 4.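

In this assay, the position on the aromatic ring para to a large group now shows a clear response: acetamido in place of methyl gives a number 11.8 percentage points higher from compound 2 to compound 4 (beyond the scatter), whereas methyl in place of hydrogen had stayed within the scatter. Acetamido in place of hydrogen likewise gives a number 18.4 percentage points higher from compound 1 to compound 4 (beyond the scatter), so this position accepts a group of 4 heavy atoms, carrying a hydrogen-bond donor and a hydrogen-bond acceptor, with no loss of inhibition at this one dose. Nothing available explains why the number rises with this change.

The compounds shown leave open whether the rise needs the whole acetamido group, which an amine or a carboxylic acid at the same position could help to test. On these data alone, it is also open whether a longer chain in place of the acetamido methyl would keep the rise, and whether acetamido would raise the number of compound 3 as well.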